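The source may hold more compounds than are shown below. What is called first, only, known or untested is meant among the compounds shown, and "the series" means these compounds.

Measured compounds:
compound 1 `CC(=O)OCC(CCn1cc(C#Cc2cc(F)cc(F)c2)c(=O)n(C(=O)c2ccccc2)c1=O)COC(C)=O` — 28900 nM
compound 2 `CC(=O)OCC(CCn1cc(C#CCc2ccccc2)c(=O)n(C(=O)c2ccccc2)c1=O)COC(C)=O` — 26800 nM

In a functional assay on MCF7 cells (Homo sapiens) for antiproliferative activity, read by MTT assay, with a stated time of 72 h (on this read-out lower numbers stand for stronger inhibition and higher numbers for weaker inhibition), compound 1 gives 28900 nM and compound 2 gives 26800 nM. Compound 2 therefore stands level with compound 1 on the numbers shown: the only step between them, a 1.1-fold lower number from compound 1 to compound 2 (0.03 log units; within the scatter), lies within the scatter, so no order between the two can be read from this assay.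

Compound 3 `CC(=O)OCC(CCn1cc(C#CC2CC2)c(=O)n(C(=O)c2ccccc2)c1=O)COC(C)=O` has not yet been measured. It differs from compound 2 by cyclopropyl in place of benzyl on a triple-bonded carbon. For the measured compounds named here, the one measured step at this position, a 1.1-fold lower number from compound 1 to compound 2 (0.03 log units; within the scatter), exchanged one group on the triple-bonded carbon for another without moving the number beyond the scatter. Going by the values given here, that single step is the only guide for the present change; it gives no sign that the group on the triple-bonded carbon sets the number in this assay, but it covers only two groups and says nothing direct about cyclopropyl.

The expectation for compound 3 is therefore a number close to that of compound 2, with no step beyond the scatter: a 1.1-fold higher number from compound 2 to compound 3 (0.05 log units; within the scatter). Compound 3 is estimated at 30000 nM, with a range from 12000 nM to 75000 nM.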

Compound 3, half-maximal inhibitory concentration: 100 nM
For compound 3 the middle estimate is 300-fold (2.48 log units) above the measured one; measured number below the stated range.
By their numbers in this assay, from the lowest: compound 3; then compounds 2 and 1 (each within the scatter of the next).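

In this assay the group on the triple-bonded carbon proves decisive for the number, which the earlier pair gave no sign of: there is a 270-fold lower number from compound 2 to compound 3 (2.43 log units; beyond the scatter) with cyclopropyl in place of benzyl, and a 290-fold lower number from compound 1 to compound 3 (2.46 log units; beyond the scatter) with cyclopropyl in place of 3,5-difluorophenyl. The two steps start from groups that each carry a six-membered aromatic ring and that stand level with each other, so the flat result for compound 1 and compound 2 reflected that one pair of groups and not a position indifferent to change. For the compounds shown here, the difference computed for the step from compound 2 to compound 3 is a smaller group without an aromatic ring, but nothing available here accounts for the large gain, and it rests on the single cyclopropyl example.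

The compounds shown leave open whether the gain is particular to cyclopropyl or extends to other small groups on the triple-bonded carbon, such as cyclobutyl, isopropyl or a straight propyl chain. They also leave open whether a polar group at this place, such as a hydroxymethyl or an amine, would keep a number near that of compound 3.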